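This account rests on a few compounds, and the source may have more. Where it says the series, first, only, none or still open, it means among the compounds named here.

Compound 1 `C=CCc1cc(C(C)=O)c(O)cc1OCCCCC#N`: in an assay on isolated protein for inhibition of leukotriene B4 receptor 1 (Homo sapiens), tested at 10 uM (a lower number here means less inhibition, a higher number more inhibition at the concentration tested (going by the name of the read-out)), compound 1 gives 92%.
Compound 2 `CCc1cc(C(C)=O)c(O)cc1OCCCCCC(C)(C)C(=O)O`: in this assay compound 2 gives 104%.

Of these two numbers compound 2 holds the higher one, and compound 1 lies lower by a gap beyond the usual scatter. Compound 3 `CCc1cc(C(C)=O)c(O)cc1OCCCCCCc1nnn[nH]1` has not yet been measured. It differs from compound 2 in a single place: (1H-tetrazol-5-yl)methyl in place of 1-carboxy-1-methylethyl on a saturated chain carbon, five bonds along the chain from an oxygen on an aromatic ring. Going by the values given here, no measured pair shows what this kind of change does here, so the expectation rests on compound 2 alone. The expected step is a number 9 percentage points lower from compound 2 to compound 3 (within the scatter), not beyond the scatter. Compound 3 is therefore estimated at 95% in this assay, ranging from 75% to 105%.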

Compound 3, a percentage reported as inhibition, at one concentration (the size of the read-out at that concentration, not a potency): 91%
Beside the measured number, compound 3's estimate is 4 percentage points above it; low and high end bracket the measured number.
By their numbers in this assay, from the lowest: compounds 3 and 1 (each within the scatter of the next); then compound 2.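

In this assay, putting (1H-tetrazol-5-yl)methyl in place of 1-carboxy-1-methylethyl gives a number 13 percentage points lower from compound 2 to compound 3 (beyond the scatter). Going by these compounds alone, this is the first readable step at this position: the change costs a modest amount of inhibition, yet compound 3 still reaches 91%, so the carboxylic acid group is not the only group here that is compatible with high inhibition at this concentration. Nothing available bears on what lies behind this step. From the compounds shown here alone, whether a primary amide or a sulfonamide in this place would give similar numbers remains open. So does how a shorter chain would fare.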